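The source may report more compounds than this note shows. Statements on the series, on what has been measured and on what is new or still open speak of the compounds shown alone.

Compound 3, with the structure `O=C(CSc1nc(Nc2ccccc2)c2ccccc2n1)Nc1ccc(Cl)cc1`, gives 12900 nM in a functional assay on PC-3 cells (Homo sapiens) for inhibition, read by MTT assay, with a stated time of 72 h (a lower number here means a stronger inhibitor, a higher number a weaker inhibitor), the second highest of the three numbers measured. Its nearest neighbour is compound 1, `O=C(CSc1nc(Nc2ccccc2)c2ccccc2n1)Nc1cccc(F)c1`, which gives 15600 nM in this assay; the step between them is a 1.2-fold lower number from compound 1 to compound 3 (0.08 log units; within the scatter). Compound 2, `C=CC(=O)Nc1cccc(NC(=O)CSc2nc(Nc3ccccc3)c3ccccc3n2)c1`, gives 8740 nM, and the step of a 1.5-fold higher number from compound 2 to compound 3 (0.17 log units; within the scatter) is likewise within the scatter, as is a 1.8-fold lower number from compound 1 to compound 2 (0.25 log units; within the scatter).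

Compound 4, `O=C(CSc1nc(Nc2ccccc2)c2ccccc2n1)Nc1ccc(C(F)(F)F)cc1`, is not yet measured. It differs from compound 3 by trifluoromethyl in place of chloro on an aromatic carbon. Among the compounds with values here, the steps that bear on this change are those that alter the group on the aryl amide: compound 1 to compound 3 and compound 2 to compound 3 exchange one substituted phenyl for another, and compound 1 to compound 2 exchanges one substituent on an aromatic carbon for another. All three stayed within the scatter, so no step beyond the scatter is expected in this assay.

Compound 4 is therefore expected to give about 12000 nM, within a range of 5000 nM to 30000 nM, a step of a 1.1-fold lower number from compound 3 to compound 4 (0.03 log units; within the scatter) that is expected to remain within the scatter.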

Compound 4, half-maximal inhibitory concentration: 10400 nM
For compound 4 the middle estimate is 1.2-fold (0.06 log units) above the measured one, and the stated range covers the measured number.
By their numbers in this assay, from the lowest: compounds 2, 4, 3 and 1 (each within the scatter of the next).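

At this position, para to a large group, trifluoromethyl with its 4 heavy atoms replaces chloro with its 1 heavy atom, and in this assay this gives a 1.2-fold lower number from compound 3 to compound 4 (0.09 log units; within the scatter), so the larger group produces no step beyond the scatter. Compound 4 also stays within the scatter of the two compounds with other aryl amide groups, with a 1.2-fold higher number from compound 2 to compound 4 (0.08 log units; within the scatter) and a 1.5-fold lower number from compound 1 to compound 4 (0.18 log units; within the scatter), and every pair among the four compounds shown now lies within the scatter. Nothing available explains this result.

As far as these compounds go, what an amine, a carboxylic acid or a longer alkyl chain on this aromatic carbon would do in this assay remains open. From the compounds shown here alone, all four compounds share one core, so the effect of changes to it also remains open.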